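Compound 3: chloro in place of methoxy, expected dose

This account rests on a few compounds, and the source may have more. Where it says the series, first, only, none or still open, it means among the compounds named here.

Among the compounds with values here, the two measured members share one core. Compound 1 is `COc1ccc(/C=C/C(=O)Nc2nc3ccc([N+](=O)[O-])cc3s2)cc1` and compound 2 is `COc1ccc(/C=C/C(=O)Nc2nc3ccc([N+](=O)[O-])cc3s2)cc1O`. In a functional assay on the whole organism (Hindlimb, strain albino) with Mus musculus as the target, in the maximal electroshock model, with a stated time of 0.5 h (on this read-out higher numbers stand for an effect only at larger amounts of compound and lower numbers for an effect already at smaller amounts), compound 1 gives 315 umol/kg; compound 2 gives 372 umol/kg, and the step of a 1.2-fold higher number from compound 1 to compound 2 (0.07 log units; within the scatter) leaves the two numbers indistinguishable. Within the data shown here, compound 1 therefore stands at one of only two measured numbers, the other lying within the scatter of it.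

Compound 3 is `O=C(/C=C/c1ccc(Cl)cc1)Nc1nc2ccc([N+](=O)[O-])cc2s1`. Relative to compound 1 the change is chloro in place of methoxy on an aromatic carbon. Among the measured compounds shown here, no measured step touches this position or this exchange: the single step available concerns a hydroxy added on an aromatic carbon elsewhere, and it stayed within the scatter. For the measured compounds named here, the series so far gives no sign that a change on this ring moves the read-out by much, but the basis for that is thin.

The working expectation is that the step of a 1.0-fold higher number from compound 1 to compound 3 (0.01 log units; within the scatter) stays within the scatter. Compound 3 is accordingly estimated at 320 umol/kg, with a range from 130 umol/kg to 800 umol/kg, the width reflecting the absence of any directly comparable step.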

Compound 3, dose for half-maximal effect: 259 umol/kg
Estimate against measurement, compound 3: 1.2-fold (0.09 log units) above; the range from low to high includes it.
By their numbers in this assay, from the lowest: compounds 3, 1 and 2 (each within the scatter of the next).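

In this assay, within the data shown here, the exchange of 4-methoxyphenyl to 4-chlorophenyl gives a 1.2-fold lower number from compound 1 to compound 3 (0.09 log units; within the scatter), the first reading at the place para to a large group itself, as the earlier step of a 1.2-fold higher number from compound 1 to compound 2 (0.07 log units; within the scatter) concerned a hydroxy added elsewhere on the ring. The methoxy, with two heavy atoms and a hydrogen-bond acceptor, can thus give way to chloro, with one heavy atom and no acceptor, without the number leaving the scatter, so for this pair neither that oxygen nor that carbon is required to hold the dose on this read-out. Nothing on hand explains why the exchange leaves the number within the scatter, and no independent measurement bears on it.

From the compounds shown here alone, one exchange at this place cannot show how tolerant the place is in general, and whether an amine, a carboxylic acid or a longer chain such as butoxy would carry the number beyond the scatter remains open. All the compounds shown also keep the same core with its nitro group, so whether the flat response on the 4-substituted phenyl survives a change there is equally unsettled.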